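From 3-iodophenyl to 4-iodophenyl on the shared core

The source may report more compounds than this note shows. Statements on the series, on what has been measured and on what is new or still open speak of the compounds shown alone.

Of the compounds shown here, three sharing one core have been measured in a functional assay on A-375 cells (Homo sapiens) for cytotoxicity, read by CCK-8 assay, with a stated time of 24 h; on this read-out higher numbers stand for weaker inhibition and lower numbers for stronger inhibition. Compound 1 `COc1cccc(-c2nc(N)c(Oc3ccccc3OC)c(Cl)n2)c1`, with a 3-methoxyphenyl group, gives 24600 nM, and compound 2 `COc1ccccc1Oc1c(N)nc(-c2ccc(Br)cc2)nc1Cl`, with a 4-bromophenyl group, gives 63 nM. Compound 3 `COc1ccccc1Oc1c(N)nc(-c2cccc(I)c2)nc1Cl`, with a 3-iodophenyl group, gives 2200 nM, the middle number of the three.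

Compound 4 `COc1ccccc1Oc1c(N)nc(-c2ccc(I)cc2)nc1Cl` has not yet been measured. It has the same atoms as compound 3, joined differently, with 4-iodophenyl in place of 3-iodophenyl on an aromatic carbon.

Among the compounds with values here, three measured steps bear on this change, and all are large. Iodo in place of methoxy gives an 11-fold lower number from compound 1 to compound 3 (1.05 log units; beyond the scatter), while the 4-bromophenyl group gives a 390-fold lower number from compound 1 to compound 2 (2.59 log units; beyond the scatter). Within the data shown here, the most relevant is a 35-fold higher number from compound 2 to compound 3 (1.54 log units; beyond the scatter), although it changes the halogen and its place together, and no measured pair separates the two. The 4-iodophenyl of compound 4 finds its nearest match in the 4-bromophenyl of compound 2 at 63 nM, so a large drop is expected, beyond the scatter. The expected change is an 18-fold lower number from compound 3 to compound 4 (1.26 log units; beyond the scatter). For compound 4 the estimated value is 120 nM, with an expected range from 30 nM to 600 nM.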

Compound 4, half-maximal inhibitory concentration: 480 nM
For compound 4 the middle estimate is 4.0-fold (0.60 log units) below the measured one, and the stated range covers the measured number.
By their numbers in this assay, from the lowest: compound 2; then compound 4; then compound 3; then compound 1.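

In this assay, within the data shown here, 4-iodophenyl in place of 3-iodophenyl gives a 4.6-fold lower number from compound 3 to compound 4 (0.66 log units; beyond the scatter), and this is the first measured pair in which the halogen stays the same and only its place on the phenyl group changes, so place alone shifts the number beyond the scatter. Keeping the place and changing only the halogen, iodo in place of bromo gives a 7.6-fold higher number from compound 2 to compound 4 (0.88 log units; beyond the scatter), so the earlier step between compound 2 and compound 3, which changed both at once, can now be seen to include a shift beyond the scatter from each change taken alone. The 4-iodophenyl group also retains a large advantage over the 3-methoxyphenyl group, with a 51-fold lower number from compound 1 to compound 4 (1.71 log units; beyond the scatter), although that step changes both the substituent and its place.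

Nothing available here explains why either the halogen or its place alters the number. Going by these compounds, it remains open how 4-chlorophenyl or 4-fluorophenyl would extend the halogen series, whether 4-methoxyphenyl would separate the effect of the methoxy group from that of its place, and how a phenyl group carrying an amine or a carboxylic acid would read.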